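Moving from an amide to a urea on the shared core

The compounds below may be only part of what the source reports. "The series", "measured", "known", "first", "only" and "open" are said of these compounds alone.

Compound 1 `O=C(Nc1cccc(-n2cc(-c3ccncc3)c(-c3ccc(Cl)c(O)c3)n2)c1)Nc1ccc(Cl)c(Cl)c1`: 1510 nM
Compound 2 `COc1cc(-c2nn(-c3cccc(NC(=O)c4ccc(Cl)c(C(F)(F)F)c4)c3)cc2-c2ccncc2)ccc1Cl`: 3100 nM
Compound 3 `O=C(Nc1cccc(-n2cc(-c3ccncc3)c(-c3ccc(Cl)c(O)c3)n2)c1)Nc1cc(C(F)(F)F)cc(C(F)(F)F)c1`: 463 nM

All three were tested in a functional assay on U-251 cells (Homo sapiens) for inhibition, read by sulforhodamine B assay, with a stated time of 48 h; a higher number here means a weaker inhibitor of growth, a lower number a stronger inhibitor of growth. Compound 2 stands highest of the three numbers: compound 1 is its nearest neighbour and compound 3 lies furthest from it, both beyond the scatter.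

Compound 4 `COc1cc(-c2nn(-c3cccc(NC(=O)Nc4cccc(C(F)(F)F)c4)c3)cc2-c2ccncc2)ccc1Cl` has not been measured. It differs from compound 2 in one place: (3-(trifluoromethyl)phenyl)amino in place of 4-chloro-3-(trifluoromethyl)phenyl on a carbonyl carbon. The new carbonyl carbon thus carries an amide-type nitrogen on each side, as in compounds 1 and 3, whose numbers in this assay are both lower than that of compound 2.

On this basis a step downward beyond the scatter is expected, of about a 3.1-fold lower number from compound 2 to compound 4 (0.49 log units; beyond the scatter). Compound 4 is estimated to give 1000 nM, within the range 350 nM to 3000 nM.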

Compound 4, concentration for 50% growth inhibition: 645 nM
For compound 4 the middle estimate is 1.6-fold (0.19 log units) above the measured one; the range from low to high includes it.
By their numbers in this assay, from the lowest: compounds 3 and 4 (each within the scatter of the next); then compound 1; then compound 2.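

In this assay, for the compounds shown here, the swap on the carbonyl carbon brings a 4.8-fold lower number from compound 2 to compound 4 (0.68 log units; beyond the scatter), the first step here between two compounds that differ in one place. The change does two things at once, adding a nitrogen with its hydrogen-bond donor and removing the chlorine, so the step belongs to the two together and to neither alone. Nothing measured here explains the step.

Open, on these data alone, is whether (4-chloro-3-(trifluoromethyl)phenyl)amino, which keeps the chlorine, would give a similar number. Also open, as far as these compounds go, is whether a methylene in place of the new nitrogen would keep the step.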